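The compounds below may be only part of what the source reports. "The series", "measured", "known", "first", "only" and "open" are said of these compounds alone.

Working notes on the series. Going by the values given here, compound 2 `COc1ccc(F)cc1CNCCCNc1ccnc2cc(C3CCCCC3)ccc12` gives 2290 nM in an ADME assay on HepG2 cells (Homo sapiens) for cytotoxicity, read by luminescence, CellTiter-Glo and ATP content, with a stated time of 72 h (a lower number here means that less compound is needed, a higher number that more compound is needed for the effect), the second highest of the three numbers in hand; compound 3 `FC(F)(F)c1cc(-c2ccc3c(NCCCNCc4ccco4)ccnc3c2)cc(C(F)(F)F)c1` gives 2410 nM, within the scatter of compound 2, while compound 1 `COc1cccc(CNCCCNc2ccnc3cc(C4CCCCC4)ccc23)c1O` gives 1080 nM, and a 2.1-fold higher number from compound 1 to compound 2 (0.33 log units; beyond the scatter) marks the only single-place step so far, at the amine end of the chain. Compound 4 `COc1ccc(F)cc1CNCCCNc1ccnc2cc(CCc3ccccc3)ccc12` differs from compound 2 elsewhere: phenethyl in place of cyclohexyl on an aromatic carbon. Among the compounds with values here, no measured step touches that position, so the cyclohexyl-to-phenethyl change has no precedent here, and no step beyond the scatter is expected. Compound 4 is therefore estimated at 2500 nM, with a range of 1000 nM to 6000 nM, and the expected step is a 1.1-fold higher number from compound 2 to compound 4 (0.04 log units; within the scatter).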

Compound 4, half-maximal effective concentration: 4240 nM
Estimate against measurement, compound 4: 1.7-fold (0.23 log units) below; low and high end bracket the measured number.
By their numbers in this assay, from the lowest: compound 1; then compounds 2, 3 and 4 (each within the scatter of the next).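

Going by these compounds alone, the first measured step at this position is a 1.9-fold higher number from compound 2 to compound 4 (0.27 log units; within the scatter) in this assay, so replacing cyclohexyl with phenethyl, 6 heavy atoms with 8 and a non-aromatic ring with an aromatic one, gives a shift that cannot be told from repeat scatter. On this one pair, the position accepts either hydrocarbon group without a step beyond the scatter. Nothing on hand explains the step.

The compounds shown leave open whether an amine or a carboxylic acid at this position would also stay within the scatter. From the compounds shown here alone, whether phenethyl behaves the same with the 2-hydroxy-3-methoxyphenyl group at the chain end also remains open.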